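The source may hold more compounds than are shown below. What is called first, only, known or untested is meant among the compounds shown, and "the series" means these compounds.

Measured compounds:
Compound 1 `CCCCCn1ccc2cc(/C(C)=C/C(=O)Nc3ccccc3OCCCC(=O)O)ccc21` gives 23 nM in an assay on Prostate gland for inhibition of steroid 5-alpha-reductase (Rattus norvegicus); on this read-out higher numbers stand for weaker inhibition and lower numbers for stronger inhibition.
Compound 2 `CCCCCCn1ccc2cc(/C(C)=C/C(=O)Nc3ccccc3OCCCC(=O)O)ccc21` gives 77 nM in this assay.
Compound 3 `CCCCCCCn1ccc2cc(/C(C)=C/C(=O)Nc3ccccc3OCCCC(=O)O)ccc21` gives 120 nM in this assay.

Compound 2 stands second highest of the three numbers in this assay; its nearest neighbour is compound 3, with a 1.6-fold higher number from compound 2 to compound 3 (0.19 log units; within the scatter), and its furthest is compound 1, with a 3.3-fold higher number from compound 1 to compound 2 (0.52 log units; beyond the scatter).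

Compound 4 `CCC(C)n1ccc2cc(/C(C)=C/C(=O)Nc3ccccc3OCCCC(=O)O)ccc21` differs from compound 2 by sec-butyl in place of hexyl on an aromatic nitrogen. The measured steps that bear on this change are those along the chain on the aromatic nitrogen: a 3.3-fold higher number from compound 1 to compound 2 (0.52 log units; beyond the scatter) and a 5.2-fold higher number from compound 1 to compound 3 (0.72 log units; beyond the scatter), while a 1.6-fold higher number from compound 2 to compound 3 (0.19 log units; within the scatter). Shortening the chain therefore went with lower numbers in this assay, and the sec-butyl group carries fewer carbons than hexyl. Among the compounds with values here, the branching of sec-butyl has no counterpart among the measured compounds, so its effect is unknown. On this basis compound 4 is expected to show a lower number than compound 2, with a 2.6-fold lower number from compound 2 to compound 4 (0.41 log units; beyond the scatter). The estimate for compound 4 in this assay is 30 nM, within a range from 8 nM to 120 nM.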

Compound 4, half-maximal inhibitory concentration: 67 nM
Compound 4: the middle estimate sits 2.2-fold (0.35 log units) below what was measured; low and high end bracket the measured number.
By their numbers in this assay, from the lowest: compound 1; then compounds 4, 2 and 3 (each within the scatter of the next).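

In this assay sec-butyl on the aromatic nitrogen stands level with the longer chains, with a 1.1-fold lower number from compound 2 to compound 4 (0.06 log units; within the scatter) against hexyl and a 1.8-fold lower number from compound 3 to compound 4 (0.25 log units; within the scatter) against heptyl, so carrying fewer carbons than hexyl brought no lower number here. Pentyl stays apart, with a 2.9-fold higher number from compound 1 to compound 4 (0.46 log units; beyond the scatter) and this shows that the carbon count alone does not order these four compounds: compound 4 has the fewest carbons, yet compound 1 has the lowest number. Nothing measured here accounts for this result.

On these data alone, whether branching or chain length sets the number of compound 4 stays open, and a straight butyl chain on the aromatic nitrogen would be the direct comparison. Also open, as far as these compounds go, is how a cyclohexyl or benzyl group in that place would read.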